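The compounds below may be only part of what the source reports. "The series", "measured", "known", "first", "only" and "open" are said of these compounds alone.

Values from a functional assay on U-251 cells (Homo sapiens) for inhibition, read by sulforhodamine B assay, with a stated time of 48 h (on this read-out higher numbers stand for weaker inhibition of growth and lower numbers for stronger inhibition of growth), are as follows.

- compound 1 `CCOC(=O)c1nn(-c2ccccc2)c(-c2ccc(Cl)cc2)c1CNC(C)(C)C` gives 73800 nM; > 559000 nM (2 entries) (several entries)
- compound 2 `CCOC(=O)c1nn(-c2ccc(Cl)cc2)c(-c2ccc(OC)cc2)c1CNC(C)(C)C` gives 431000 nM; > 523000 nM (2 entries) (several entries)
- compound 3 `CC(C)(C)NCc1c(C(=O)O)nn(-c2ccccc2)c1-c1ccc(Cl)cc1` gives > 652000 nM (a limit)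

Compound 3 has no single number in this assay and its entry of > 652000 nM is a limit. It therefore gives a bound and no exact position against the other two compounds.

Compound 4 `Cc1ccc(-c2c(CNC(C)(C)C)c(C(=O)O)nn2-c2ccccc2)cc1` keeps the rest of compound 3 and has methyl in place of chloro on an aromatic carbon, para to a large group, so that 4-chlorophenyl becomes 4-methylphenyl (methyl in place of chloro on an aromatic carbon).

Among the compounds with values here, no pair of measured compounds differs in one place only, so the size of this change in this assay has no direct measure. The expectation is no step beyond the scatter, with growth inhibition remaining weak. This expectation rests on compound 3 and its limit of > 652000 nM together with the single-atom size of the change. The estimated change is a step that the limit leaves unreadable from compound 3 to compound 4 and remains a small one. Compound 4 is estimated at 690000 nM with an expected range of 250000 nM to 900000 nM in this read-out. A report of a limit alone, without a number, is also expected to be the likelier result.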

Compound 4, concentration for 50% growth inhibition: > 688000 nM
Compound 4: no number, only a limit (the forecaster's own chance of this, stated with the estimate: 75%); the middle value lies beyond the limit too.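

In this assay compound 3 gives > 652000 nM as a limit only. Within the data shown here, compound 4 gives > 688000 nM as a limit only, so no step between the two can be read. The compounds shown leave open whether, in this assay and with the rest of the structure kept, 4-methylphenyl in place of 4-chlorophenyl changes growth inhibition at all.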